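Acid Becomes Amide: Expected Tolerance in Cell Culture

The source may hold more compounds than are shown below. What is called first, only, known or untested is meant among the compounds shown, and "the series" means these compounds.

Of the compounds shown here, three sharing the same saturated carbon framework have been tested in an ADME assay (Gallus gallus) for cytotoxicity, read by microscopy, with a stated time of 24 h; a lower number here means that less compound is tolerated, a higher number that more compound is tolerated. Compound 1 `O=C1C2CCC3C(CCCC13)C2` carries a ketone, and in this assay compound 1 gives 2400000 nM. Compound 2 `O[C@@H]1C2CCCC3C[C@@H]1CC[C@@H]32` carries a hydroxy group, and compound 2 gives 750000 nM. Compound 3 `O=C(O)C12CCCC3CC(CCC31)C2` carries a carboxy group, and compound 3 gives 10000000 nM, the highest of the three numbers, so compound 3 is the one the cells tolerate most. Compound 1 lies closest to it and compound 2 furthest away, and both of those gaps lie beyond the usual scatter.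

Compound 4 `NC(=O)C12CCCC3CC(CCC31)C2` has not yet been measured. It differs from compound 3 in a single place: amino in place of hydroxy on a carbonyl carbon. Among the compounds with values here, no pair of measured compounds shows the same change, so the only guide is the three measured numbers and the small size of the alteration, which exchanges one small group for another.

Because compound 3 stands at 10000000 nM, the top of the set, the step of a 2.0-fold lower number from compound 3 to compound 4 (0.30 log units; within the scatter) is expected to be small, and if it leaves the scatter, to run toward a lower number. In this assay compound 4 is therefore estimated at 5000000 nM, with a likely range from 2000000 nM to 12000000 nM.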

Compound 4, minimum cytotoxic concentration: 5200000 nM
Beside the measured number, compound 4's estimate is 1.0-fold (0.02 log units) below it; the measured number falls inside the stated range.
By their numbers in this assay, from the lowest: compound 2; then compound 1; then compounds 4 and 3 (each within the scatter of the next).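

In this assay, amino in place of hydroxy on a carbonyl carbon gives a 1.9-fold lower number from compound 3 to compound 4 (0.28 log units; within the scatter), so this single exchange does not separate the two compounds. Within the data shown here, compounds 1, 2 and 3 offered no pair differing in one place, which makes this the first direct reading of any one change on the shared core, and it shows that, at this position, the carboxy-to-carbamoyl swap leaves the reading inside the normal spread of repeat measurements. No measurement of any property bears on why these two numbers sit so close.

The compounds shown leave open whether a methyl ester, a nitrile or an amide carrying a methyl group on its nitrogen, placed on the same saturated ring carbon, would also stay within the scatter of compound 3, or whether one of them would move clearly away from it. This is also a single pair, so it cannot say whether amino in place of hydroxy on a carbonyl carbon would give a similarly small step on a different core.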